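The source may report more compounds than this note shows. Statements on the series, on what has been measured and on what is new or still open speak of the compounds shown alone.

Working notes on the series, read in an ADME assay on microsomes (Mus musculus) for metabolic stability, read by LC-MS, using NADPH, with a stated time of 1 h, tested at 1 uM; on this read-out lower numbers stand for slow clearance and higher numbers for fast clearance. Compound 1 (`Nc1n[nH]c2cc(-c3ccc(=O)n(Cc4ccccc4F)c3)ccc12`) gives < 10 mL.min-1.g-1, which is a limit of the assay and not a number. Compound 2 (`Nc1n[nH]c2cc(-c3ccc(=O)n(Cc4cccc(Cl)c4)c3)ccc12`) gives < 10 mL.min-1.g-1, which is likewise only a limit. The evidence so far is the limit of < 10 mL.min-1.g-1 in this assay, at which 2 of the 2 values shown sit. Compound 3 (`Nc1n[nH]c2cc(-c3ccc(=O)n(Cc4cccc(F)c4)c3)ccc12`) departs from compound 2 by one change, fluoro in place of chloro on an aromatic carbon, meta to a large group: fluoro in place of chloro on an aromatic carbon. Going by the values given here, the one measured step that bears on this is a step that the two limits leave unreadable from compound 1 to compound 2, and it offers no size to carry over. Resting on that step, no change beyond the scatter is expected in this assay, in either direction. The expected step is a step that the limit leaves unreadable from compound 2 to compound 3. For compound 3 the estimate is 7 mL.min-1.g-1, with an expected range from 4 mL.min-1.g-1 to 14 mL.min-1.g-1.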

Compound 3, intrinsic clearance in microsomes: < 10 mL.min-1.g-1
Compound 3 gave a limit, no number; the forecaster's own chance of this, stated with the estimate: 80%; the middle value does not contradict the limit.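

Compound 1, compound 2 and compound 3 all sit at a limit, not a number, so no step among them can be read in this assay: the limit of < 10 mL.min-1.g-1 in this assay, at which 3 of the 3 values shown sit.

The compounds shown leave open how the clearance of these three compounds compares, and whether chloro and fluoro differ at all in this assay.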